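A few compounds are considered here, and "the series" means these few. Any claim that something is new, unique, unknown or untested is made for them only; others in the source may bear on it.

Of the compounds shown here, two built on one shared core have been measured so far in an in vitro ADME assay on microsomes from liver (Mus musculus) for metabolic stability; on this read-out lower numbers stand for slow clearance and higher numbers for fast clearance. In that assay compound 1 `COCc1nc2nc(C)cc(Nc3ccc(C(F)(F)F)cc3)n2n1` gives 13.3 mL.min-1.g-1 and compound 2 `COCCc1nc2nc(C)cc(Nc3ccc(S(F)(F)(F)(F)F)cc3)n2n1` gives 14.1 mL.min-1.g-1. Compound 2 therefore stands within the scatter of compound 1, and the two numbers set no order. Still unmeasured is compound 3 `Cc1cc(Nc2ccc(S(F)(F)(F)(F)F)cc2)n2nc(C3CC3)nc2n1`, which carries cyclopropyl in place of 2-methoxyethyl on an aromatic carbon of a five-membered aromatic ring with 3 nitrogen (cyclopropyl in place of 2-methoxyethyl on an aromatic carbon). Among the measured compounds shown here, no measured pair isolates this change, so any expectation rests on little. A small downward step in this assay is expected, probably no larger than the scatter. The estimate amounts to a 1.3-fold lower number from compound 2 to compound 3 (0.13 log units; within the scatter). For compound 3 the estimated intrinsic clearance is 10.5 mL.min-1.g-1, with an expected range from 4.5 mL.min-1.g-1 to 24 mL.min-1.g-1.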

Compound 3, intrinsic clearance in microsomes: 12.6 mL.min-1.g-1
Beside the measured number, compound 3's estimate is 1.2-fold (0.08 log units) below it; measured number inside the range.
By their numbers in this assay, from the lowest: compounds 3, 1 and 2 (each within the scatter of the next).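

Among the compounds shown here, compound 2 and compound 3 form the first pair here that differs in one place only, so this position can now be read on its own. In this assay, cyclopropyl in place of 2-methoxyethyl on this aromatic carbon, between two ring nitrogen atoms, gives a 1.1-fold lower number from compound 2 to compound 3 (0.05 log units; within the scatter) and so sets no order between the two. The open chain and its one hydrogen-bond acceptor leave, a three-membered ring without any acceptor enters, and the read-out stays within the scatter, though nothing at hand accounts for this.

On these data alone, whether an amine, a carboxylic acid or a longer chain on this carbon would move the number beyond the scatter remains open. Also open, as far as these compounds go, is whether the same change would read alike in a compound carrying trifluoromethyl, as compound 1 does.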